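The source may hold more compounds than are shown below. What is called first, only, known or untested is meant among the compounds shown, and "the series" means these compounds.

Measured so far in a functional assay on NFS-60 cells (Mus musculus) for inhibition, read by MTT assay, with a stated time of 72 h; on this read-out lower numbers stand for stronger inhibition and higher numbers for weaker inhibition: compound 1 `Cc1ccc(C(=O)OC2(C(=O)Nc3ccc([N+](=O)[O-])cc3)CCCCC2)cc1` gives 45.4 nM; compound 2 `O=C(OC1(C(=O)Nc2ccc([N+](=O)[O-])cc2)CCCCC1)c1ccc([N+](=O)[O-])cc1` gives 7.7 nM.

Going by the values given here, compound 2 holds the lowest of the two numbers, with a 5.9-fold lower number from compound 1 to compound 2 (0.77 log units; beyond the scatter) as the single step recorded, a step that turned on the nitro group of the ester aryl ring.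

Compound 3 `O=C(/C=C/c1ccccc1)OC1(C(=O)Nc2ccc([N+](=O)[O-])cc2)CCCCC1` is not yet measured. Its change from compound 2 is 2-phenylethenyl in place of 4-nitrophenyl on a carbonyl carbon. Among the compounds with values here, the one step that bears on it, the change from compound 1 to compound 2, removed in reverse what compound 3 now loses, so a higher number in this assay is expected, of moderate size.

Compound 3 is expected to give 35 nM, within 12 nM to 100 nM, which means a step of a 4.5-fold higher number from compound 2 to compound 3 (0.66 log units; beyond the scatter) expected from compound 2 to compound 3.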

Compound 3, half-maximal inhibitory concentration: 50.5 nM
For compound 3 the middle estimate is 1.4-fold (0.16 log units) below the measured one, within the range that was stated.
By their numbers in this assay, from the lowest: compound 2; then compounds 1 and 3 (each within the scatter of the next).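

On a carbonyl carbon, in this assay, 2-phenylethenyl in place of 4-nitrophenyl gives a 6.6-fold higher number from compound 2 to compound 3 (0.82 log units; beyond the scatter) and so does not keep the low number of compound 2. 2-phenylethenyl in place of 4-methylphenyl gives a 1.1-fold higher number from compound 1 to compound 3 (0.05 log units; within the scatter) and shows no separable difference between these two groups, leaving 4-nitrophenyl alone apart among the three. No supporting data bear on the reason for this result. From the compounds shown here alone, whether the low number depends on the nitro group itself or would also hold with a nitrile or a carboxylic acid on the ring remains open. Also open, going by these compounds, is whether a nitro group on the ring of 2-phenylethenyl would lower the number.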